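Replacing a nitrile-bearing ring on the core of compound 1

This account rests on a few compounds, and the source may have more. Where it says the series, first, only, none or still open, it means among the compounds named here.

Compound 1 `N#Cc1ccc(-c2nc(C(c3ccc(F)cc3)c3ccc(F)cc3)sc2CC(=O)O)cc1` gives 30% in an in vitro functional assay on HEK285-7 cells for antagonist activity at prostaglandin D2 receptor 2 (Homo sapiens), read by BRET and beta-arrestin recruitment (a lower number here means a smaller maximal response, a higher number a larger maximal response), the lowest of the three measured values; compound 2 `COc1ccc(C(c2ccccc2)c2nc(-c3ccc(Cl)cc3)c(CC(=O)O)s2)cc1` gives 80% and compound 3 `COc1ccc(C(c2ccccn2)c2nc(-c3ccc(Cl)cc3)c(CC(=O)O)s2)cc1` gives 80%, each beyond the scatter above compound 1. Among the compounds with values here, the one single-place step on record, no change at the digits printed from compound 2 to compound 3 (within the scatter), concerns a different part of the molecule. Compound 4 `Cc1cc(-c2nc(C(c3ccc(F)cc3)c3ccc(F)cc3)sc2CC(=O)O)ccn1` differs from compound 1 as follows: 2-methylpyridin-4-yl in place of 4-cyanophenyl on an aromatic carbon. Within the data shown here, no measured step tests this exchange on this ring carbon, so the only guide is that a phenyl-to-pyridyl swap elsewhere left this assay unchanged; he therefore expects a number 10 percentage points higher from compound 1 to compound 4 (within the scatter), a step that may well stay within the scatter. For compound 4 he estimates 40%, within a range of 15% to 70%.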

Compound 4, largest response reached (reported as efficacy), in percent of the reference or control that the assay uses: 80%
Compound 4: middle estimate off by 40 percentage points, on the low side; measured number above the stated range.
By their numbers in this assay, from the lowest: compound 1; then compounds 2, 3 and 4 (each within the scatter of the next).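

In this assay the exchange of 4-cyanophenyl for 2-methylpyridin-4-yl on this aromatic carbon brings a number 50 percentage points higher from compound 1 to compound 4 (beyond the scatter) on the shared core. The earlier compounds showed only a phenyl-to-pyridyl swap elsewhere that left the number unchanged, so this is the first position shown to move the maximal response. Nothing on hand explains the step. The compounds shown leave open which part of the exchange carries it: the loss of the nitrile, the ring nitrogen or the methyl. A pyridin-4-yl without the methyl, or a 4-methylphenyl, would separate these.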